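Compound 3 and a Methyl Removed from Oxygen

The source may hold more compounds than are shown below. What is called first, only, known or untested is meant among the compounds shown, and "the series" means these compounds.

Measured so far:
- compound 1 `COc1ccccc1/C=C/[C@@](C)(/C=C/c1ccc(O)cc1)CCC=C(C)C` gives 62%
- compound 2 `COc1ccc(/C=C/[C@@](C)(/C=C/c2ccc(O)cc2)CCC=C(C)C)cc1` gives 52%

Going by the values given here, in a functional assay on THP-1 cells (Homo sapiens) for inhibition, with a stated time of 48 h, tested at 50 uM (a higher number here means more inhibition of growth at the concentration tested, a lower number less inhibition of growth), compound 2 stands at 52%, and compound 1, the only other measured compound, lies within the scatter of it. Compound 3 `CC(C)=CCCC(C)(/C=C/c1ccc(O)cc1)/C=C/c1ccc(O)cc1` arises from compound 2 through a single change, (hydrogen in place of methyl on an oxygen on an aromatic ring), with hydrogen in place of methyl on an oxygen on an aromatic ring.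

Among the compounds with values here, only one measured step is available, and it bears on this change only loosely. That step is a number 10 percentage points lower from compound 1 to compound 2 (within the scatter), with 4-methoxyphenyl in place of 2-methoxyphenyl, and the methyl stays on its oxygen throughout. Within the data shown here, no measured pair shows what happens when that methyl is replaced by hydrogen, so the expectation remains uncertain.

On this limited evidence, no change beyond the scatter is expected in this assay, and the estimated size is a number 5 percentage points higher from compound 2 to compound 3 (within the scatter). For compound 3 the expected value is 57%, within an estimated range from 38% to 76%.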

Compound 3, percent growth inhibition at one concentration: 66%
Compound 3: the middle estimate sits 9 percentage points below what was measured, and the stated range covers the measured number.
By their numbers in this assay, from the lowest: compounds 2, 1 and 3 (each within the scatter of the next, the first and the last beyond it).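

Going by these compounds alone, replacing the methyl with hydrogen on an oxygen on an aromatic ring gave a number 14 percentage points higher from compound 2 to compound 3 (beyond the scatter) in this assay, so this oxygen substituent is the first place where a single change registers beyond the usual scatter. The earlier step, a number 10 percentage points lower from compound 1 to compound 2 (within the scatter), exchanged 2-methoxyphenyl for 4-methoxyphenyl and kept the methyl on its oxygen, so it could not show this; the new pair shows that losing that methyl can matter even though the step is modest. Nothing available explains the gain, and no supporting measurement bears on why hydrogen reads differently from methyl here.

This rests on one pair of compounds, and the compounds shown leave open whether the same replacement would have a similar effect on the 2-methoxyphenyl group of compound 1. They also leave open how this assay would respond to an ethyl group on that oxygen, or to an amine or a carboxylic acid on the aromatic ring in place of the oxygen group, and a reading at a single concentration cannot say how the compounds would compare across a range of concentrations.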